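Three phenyl-bearing lactams and a fourth to come

A few compounds are considered here, and "the series" means these few. Any claim that something is new, unique, unknown or untested is made for them only; others in the source may bear on it.

All numbers here come from an in vitro ADME assay on microsomes from liver (Rattus norvegicus) for metabolic stability, read by LC-MS, with a stated time of 15 min; a higher number here means faster removal of the compound, a lower number slower removal.

compound 1, `O=C1CCC(c2ccccc2)=NN1c1ccccc1`: 0.497 mL.min-1.g-1
compound 2, `O=c1ccc(-c2ccccc2)cn1-c1ccccc1`: 0.486 mL.min-1.g-1
compound 3, `O=c1[nH]cc(-c2ccccc2)cc1-c1ccccc1`: 0.822 mL.min-1.g-1

The three values sit close together. Compound 3 gives the largest of the three numbers, yet its gap to compound 1 and its gap to compound 2 both fall within the usual scatter of this assay, so none of the three stands apart from the others on the evidence available.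

Compound 4, `O=c1c(-c2ccccc2)cc(-c2ccccc2)cn1-c1ccccc1`, has not yet been measured. It differs from compound 3 in one place: phenyl in place of hydrogen on an aromatic nitrogen. Among the measured compounds shown here, no pair of measured compounds differs by exactly this change, so there is no measured step to lean on; the comparison of compound 2 with compound 3 involves two changes at once and cannot be read as a single step.

On that basis the step from compound 3 to compound 4 is expected to be small, a 1.1-fold higher number from compound 3 to compound 4 (0.04 log units; within the scatter), most likely within the scatter and with no firm direction. Compound 4 is accordingly estimated at 0.9 mL.min-1.g-1 in this assay, with a range from 0.4 mL.min-1.g-1 to 2 mL.min-1.g-1.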

Compound 4, intrinsic clearance in microsomes: 0.052 mL.min-1.g-1
Estimate against measurement, compound 4: 17-fold (1.24 log units) above, outside the stated range (below it).
By their numbers in this assay, from the lowest: compound 4; then compounds 2, 1 and 3 (each within the scatter of the next).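

In this assay, among the compounds shown here, phenyl in place of hydrogen on the aromatic nitrogen gives a 16-fold lower number from compound 3 to compound 4 (1.20 log units; beyond the scatter) and is the first single change to reach beyond the scatter. Phenyl in place of hydrogen on an aromatic carbon gives a 9.3-fold lower number from compound 2 to compound 4 (0.97 log units; beyond the scatter) as well, so among these compounds the low number appears only in compound 4, where the nitrogen and that carbon both carry phenyl, and not in compound 2 or compound 3, which each lack one of the two. Nothing available speaks to the reason for either step.

On these data alone, whether a methyl group or a short chain ending in an amine on that nitrogen would give a similar step remains open. The compounds shown also leave open how a carboxylic acid on one of the phenyl rings would alter the number.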